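The compounds below may be only part of what the source reports. "The series", "measured", "known", "first", "only" and "open" are said of these compounds alone.

Measured so far:
compound 1, `COc1ccccc1NC(=O)N[C@@H](C)c1ccccc1`, gives 98%
compound 2, `CC(=O)c1ccccc1NC(=O)N[C@H](C)c1ccccc1`, gives 96%

Both numbers come from an ADME assay on the whole organism with Oryza sativa as the target, tested at 0.1 uM; a higher number here means a weaker effect of the compound at the concentration tested, a lower number a stronger effect. Compound 2 gives 96% there and compound 1 gives 98%; the two lie within the scatter of each other, so on the numbers shown compound 2 stands level with compound 1 and nothing separates them. The next compound is compound 3, `CC(=O)c1ccccc1NC(=O)N[C@@H](C)c1ccccc1`, to be measured in this assay. Its difference from compound 2 is the two compounds have the same atoms and bonds and differ only in configuration as drawn: 1 of 1 stereo elements differ; a stereocentre at a saturated chain carbon is drawn R in compound 2 and S in compound 3. Among the compounds with values here, no step between measured compounds is at hand for this change, so the only guide is that compounds 1 and 2 sit together in this assay. The step is expected to be none beyond the scatter, estimated at no change at the digits printed from compound 2 to compound 3 (within the scatter). Compound 3 is expected at 96% in this assay, within a range from 86% to 100%.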

Compound 3, a percentage reported as activity, at one concentration (the size of the read-out at that concentration, not a potency): 100%
For compound 3 the middle estimate is 4 percentage points below the measured one; measured number inside the range.
By their numbers in this assay, from the lowest: compounds 2, 1 and 3 (each within the scatter of the next).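

In this assay, the stereocentre at the saturated chain carbon now has a direct comparison, and inverting it as drawn gives a number 4 percentage points higher from compound 2 to compound 3 (within the scatter), so the R and S forms are not separated at this concentration. Acetyl in place of methoxy on an aromatic carbon gives a number 2 percentage points higher from compound 1 to compound 3 (within the scatter), so this exchange is not resolved by the assay either. The configuration comparison is a matched one, with no other structural change involved: the fact that compounds 2 and 3 differ only in the configuration as drawn

The three compounds therefore show no effect of either change beyond the scatter in this assay, and this single concentration gives no measure of potency. Still open, as far as these compounds go, is whether an amine or a carboxylic acid on that aromatic carbon, or a longer chain at the stereocentre, would move the read-out beyond the scatter.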